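This account rests on a few compounds, and the source may have more. Where it says the series, first, only, none or still open, it means among the compounds named here.

The series shares the core of compound 1 `COc1cc(C(c2ccc(O)c(OC)c2)[C@@H](C)[C@H](C)CO)ccc1O`, and the compounds differ only in the group on a saturated chain carbon bound to two aromatic carbons. In a functional assay on HL-60 cells (Homo sapiens) for cytotoxicity, read by WST assay, with a stated time of 48 h (on this read-out higher numbers stand for weaker inhibition and lower numbers for stronger inhibition), compound 1 reports a limit of > 100000 nM, not a number. Compound 2 `CCCCC[C@H](C(C)C)C(c1ccc(O)c(OC)c1)c1ccc(O)c(OC)c1` gives 9600 nM in this assay, and compound 3 `COc1cc(C(c2ccc(O)c(OC)c2)[C@H](C)[C@H](C)CF)ccc1O` gives 56000 nM. Compound 3 thus holds the higher of the two numbers, with compound 2 nearest at a 5.8-fold higher number from compound 2 to compound 3 (0.77 log units; beyond the scatter), while the step of an at least 1.7-fold lower number from compound 1 to compound 3 (0.25 log units; that floor lies within the scatter) starts from a limit. The step of an at least 10-fold lower number from compound 1 to compound 2 (1.01 log units; beyond the scatter) shows how far a move away from the 2-(hydroxymethyl)-1-methylpropyl group can carry the number.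

Compound 4 `COc1cc(C(c2ccc(O)c(OC)c2)[C@@H](CO)C(C)C)ccc1O` is the next step: 1-(hydroxymethyl)-2-methylpropyl in place of 2-(fluoromethyl)-1-methylpropyl on a saturated chain carbon bound to two aromatic carbons. The change brings back a hydroxymethyl group, as in compound 1, and works against the move from compound 1 to compound 3, whose step an at least 1.7-fold lower number from compound 1 to compound 3 (0.25 log units; that floor lies within the scatter) was small at best. The expected step is therefore upward, toward the limit of compound 1, though that limit of > 100000 nM in this assay, at which 1 of the 3 values shown sits, leaves its full size open. Compound 4 is expected to show a 1.8-fold higher number from compound 3 to compound 4 (0.25 log units; within the scatter) in this assay. Compound 4 is estimated at 100000 nM, between 40000 nM and 300000 nM, with a fair chance that only a limit is reported.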

Compound 4, half-maximal inhibitory concentration: > 100000 nM
Compound 4 ended at the assay's limit; the forecaster's own chance of this, stated with the estimate: 50%; the middle value sits exactly at the limit.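

Exchanging the fluorine-bearing group for 1-(hydroxymethyl)-2-methylpropyl gives an at least 1.7-fold higher number from compound 3 to compound 4 (0.25 log units; that floor lies within the scatter) in this assay, so this change cannot be told apart from the scatter, and fluorine and hydroxyl are not separated at this position. Against the 1-isopropylhexyl group the same entering group gives an at least 10-fold higher number from compound 2 to compound 4 (1.01 log units; beyond the scatter), which repeats in size the earlier step from the other hydroxymethyl-bearing group and shows that a second arrangement of the hydroxymethyl group also fails to approach compound 2. Compound 1 and compound 4 both end at a limit, so the step between them cannot be read and the two arrangements of the group cannot be ranked: the limit of > 100000 nM in this assay, at which 2 of the 4 values shown sit.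

The compounds shown leave open whether it is the length of the 1-isopropylhexyl chain or the absence of a hydroxyl group that sets compound 2 apart, since the two go together here. They also leave open whether a longer chain ending in hydroxymethyl, or an amine or a carboxylic acid at the end of the group, would give a number that can be read in this assay.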